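Tert-butyl to bromo: expected tolerance of compound 4

A few compounds are considered here, and "the series" means these few. Any claim that something is new, unique, unknown or untested is made for them only; others in the source may bear on it.

Compound 1 `C[C@H]1[C@H](NCc2ccc(C(C)(C)C)s2)C[C@H]2C[C@@H]1C2(C)C` is assessed in an ADME assay on MDCK cells (Canis lupus familiaris) for cytotoxicity, read by microscopy, with a stated time of 48 h (a lower number here means that less compound is tolerated, a higher number that more compound is tolerated), where compound 1 gives 780 nM. This is the lowest of the three numbers in hand. Compound 2 `C[C@H]1[C@H](NCc2cc(C3CC3)cs2)C[C@H]2C[C@@H]1C2(C)C` gives 25000 nM, and compound 3 `CCCc1ccsc1CN[C@@H]1C[C@H]2C[C@@H]([C@H]1C)C2(C)C` gives 50000 nM; both gaps from compound 1 lie beyond the scatter, so compound 1 is the least tolerated of the three. Going by the values given here, no pair in this set differs in a single place, so no measured step is available. Compound 4 `C[C@H]1[C@H](NCc2ccc(Br)s2)C[C@H]2C[C@@H]1C2(C)C` differs from compound 1 as follows: bromo in place of tert-butyl on an aromatic carbon. Since the two compounds without tert-butyl show the higher numbers, the expected step is a 6.4-fold higher number from compound 1 to compound 4 (0.81 log units; beyond the scatter), toward a higher number and beyond the scatter. Compound 4 is estimated at 5000 nM, within 1500 nM to 20000 nM.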

Compound 4, minimum cytotoxic concentration: 43000 nM
Compound 4: middle estimate off by 8.6-fold (0.93 log units), on the low side, and the stated range ends below it.
By their numbers in this assay, from the lowest: compound 1; then compounds 2, 4 and 3 (each within the scatter of the next).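

In this assay, going by these compounds alone, bromo in place of tert-butyl on this aromatic carbon next to the ring sulfur gives a 55-fold higher number from compound 1 to compound 4 (1.74 log units; beyond the scatter), the first single-place step. The low number of compound 1 is therefore tied to tert-butyl at this position, not to the shared core alone. No measured evidence bears on the cause of this step.

From the compounds shown here alone, whether methyl, isopropyl or chloro at this position would give a number nearer to that of compound 1 or compound 4 remains open. Going by these compounds, an amine or a carboxylic acid here is equally open.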